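A few compounds are considered here, and "the series" means these few. Any claim that something is new, unique, unknown or untested is made for them only; others in the source may bear on it.

Measured compounds:
compound 1 `CC(C)(C)c1ccc(C(=O)N2CCC3(CC2)C(=O)N(CC(=O)N2CCNCC2)CN3c2ccccc2)cc1`, 22000 nM
compound 2 `CCOC(=O)C1CCN(C(=O)CN2CN(c3ccccc3)C3(CCN(C(=O)c4ccc(C5CCCCC5)cc4)CC3)C2=O)CC1`, 900 nM
compound 3 `CS(=O)(=O)NCCCNC(=O)CN1CN(c2ccccc2)C2(CCN(C(=O)c3ccc(C4CCCCC4)cc3)CC2)C1=O`, 3800 nM

In an assay on HEK293 cells for displacement of a labelled ligand from NPC1-like intracellular cholesterol transporter 1 (Homo sapiens) (on this read-out lower numbers stand for stronger inhibition and higher numbers for weaker inhibition), compound 1 stands highest of the three numbers: compound 3 comes nearest, and compound 2 lies furthest away with the lowest number of the set. For the measured compounds named here, the only step between compounds that differ in one place is a 4.2-fold higher number from compound 2 to compound 3 (0.63 log units; beyond the scatter), a modest change on the carbonyl carbon of the side chain, where a (3-(methanesulfonamido)propyl)amino group replaces a 4-(ethoxycarbonyl)piperidin-1-yl group.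

The new compound 4 `CC(C)(C)c1ccc(C(=O)N2CCC3(CC2)C(=O)N(CC(=O)N2CCN(S(C)(=O)=O)CC2)CN3c2ccccc2)cc1` follows from compound 1 by methylsulfonyl in place of hydrogen on an amine nitrogen in a ring. Going by the values given here, no measured step shows this same change; the step from compound 2 to compound 3 touches the same region of the molecule but exchanges a different group, and it was modest in size. That leaves little ground for expecting a large step in this assay. Since compound 1 gives 22000 nM, the highest number of the set, a modest move toward lower numbers is estimated, and the expected step is a 2.8-fold lower number from compound 1 to compound 4 (0.44 log units; beyond the scatter). For compound 4 the value in this assay is estimated at 8000 nM, with a range from 2500 nM to 25000 nM.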

Compound 4, half-maximal inhibitory concentration: 19000 nM
The estimate for compound 4 lay 2.4-fold (0.38 log units) below the measured number, and the stated range covers the measured number.
By their numbers in this assay, from the lowest: compound 2; then compound 3; then compounds 4 and 1 (each within the scatter of the next).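

In this assay, putting methylsulfonyl on the amine nitrogen of the piperazin-1-yl group gave a 1.2-fold lower number from compound 1 to compound 4 (0.06 log units; within the scatter) and so no change that can be told from the scatter. This shows that, at this ring nitrogen, the free hydrogen can give way to a group of four heavy atoms without a readable shift in the number, something the earlier exchange of one entire side-chain group for another, a 4.2-fold higher number from compound 2 to compound 3 (0.63 log units; beyond the scatter), could not show. Nothing in the data explains why the number holds steady under this change.

On these data alone, it remains open whether the same nitrogen would tolerate other substituents in the same way, such as a plain methyl, an acetyl group or a longer chain ending in a carboxylic acid, or whether one of these would move the number beyond the scatter. Also open, as far as these compounds go, is whether the 4-(ethoxycarbonyl)piperidin-1-yl group of compound 2, placed on the core of compound 1 with its tert-butyl group, would shift the number in this read-out at all.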